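The source may report more compounds than this note shows. Statements on the series, on what has been measured and on what is new or still open speak of the compounds shown alone.

Read-outs in an ADME assay on MDBK cells (Bos taurus) for cytotoxicity (on this read-out higher numbers stand for lower toxicity in this test and lower numbers for higher toxicity in this test), for three compounds with a shared core:

- Compound 1 `COc1cccc(Cn2ccc3nc(-c4ccccc4)nc-3c2)c1` gives > 100000 nM as a limit
- Compound 2 `Brc1ccccc1Cn1ccc2nc(-c3ccccc3)nc-2c1` gives > 100000 nM as a limit
- Compound 3 `Brc1ccc(Cn2ccc3nc(-c4ccccc4)nc-3c2)cc1` gives 83000 nM as a true number

Compound 3 is the only one of the three with a true number. Compound 4 `O=C(O)c1ccc(Cn2ccc3nc(-c4ccccc4)nc-3c2)cc1` carries carboxy in place of bromo on an aromatic carbon, para to a large group, a change counted as carboxy in place of bromo on an aromatic carbon in full. Two measured steps reach compound 3, namely an at least 1.2-fold lower number from compound 1 to compound 3 (0.08 log units; that floor lies within the scatter) and an at least 1.2-fold lower number from compound 2 to compound 3 (0.08 log units; that floor lies within the scatter) as well. Both are floors within the scatter, and neither brings in carboxy. With only those floors to go on, no step beyond the scatter is expected in this assay here. The expected step is a 1.2-fold higher number from compound 3 to compound 4 (0.08 log units; within the scatter) as an estimate. For compound 4 the estimated value is 100000 nM with an expected range from 50000 nM to 200000 nM overall.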

Compound 4, half-maximal cytotoxic concentration: > 100000 nM
Compound 4 ended at the assay's limit (the forecaster's own chance of this, stated with the estimate: 60%); the middle value sits exactly at the limit.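

In this assay, carboxy in place of bromo on the aromatic carbon para to a large group gives an at least 1.2-fold higher number from compound 3 to compound 4 (0.08 log units; that floor lies within the scatter). Among these compounds, this shows that the position can carry a group with a hydrogen-bond donor and acceptor with no sign of a lower number, which the earlier compounds did not show. The step remains only a floor, because the read-out stops at a limit: the limit of > 100000 nM in this assay, at which 3 of the 4 values shown sit.

Still open, going by these compounds, is how an amine or a longer chain at this position would read in this assay.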